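From Trifluoromethyl to 4-Methylphenyl on the Sulfonyl Sulfur

A few compounds are considered here, and "the series" means these few. Any claim that something is new, unique, unknown or untested is made for them only; others in the source may bear on it.

In an ADME assay on BJ cells (Homo sapiens) for cytotoxicity, with a stated time of 72 h (a lower number here means that less compound is needed, a higher number that more compound is needed for the effect), compound 1 (`C=C[C@@](C)(/C=C/c1ccc(OCc2ccccc2)cc1)CCC=C(C)C`) gives > 36600 nM as a limit of the assay. Compound 2 (`C=C[C@@](C)(/C=C/c1ccc(OS(=O)(=O)C(F)(F)F)cc1)CCC=C(C)C`) gives > 36600 nM and this too is a limit. Among the measured compounds shown here, the one measured step that the two limits leave unreadable from compound 1 to compound 2 has no readable size, and the limit of > 36600 nM in this assay, at which 2 of the 2 values shown sit, is the only evidence to hand. Compound 3 (`C=C[C@@](C)(/C=C/c1ccc(OS(=O)(=O)c2ccc(C)cc2)cc1)CCC=C(C)C`) carries 4-methylphenyl in place of trifluoromethyl on a sulfonyl sulfur. Compound 2 at > 36600 nM is the only anchor, so no clear step is expected in this assay in either direction. The expected change is a number no higher from compound 2 to compound 3 (the limit leaves the size open) in this estimate. For compound 3 the expected value is 36600 nM (estimated range 15000 nM to 60000 nM).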

Compound 3, half-maximal effective concentration: > 36600 nM
Compound 3 gave a limit, no number; the forecaster's own chance of this, stated with the estimate: 80%; the middle value sits exactly at the limit.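

No step between compound 2 and compound 3 can be read in this assay, as both values are limits: the limit of > 36600 nM in this assay, at which 3 of the 3 values shown sit.

The compounds shown leave open whether any of the three actually differ in this read-out.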